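The source may report more compounds than this note shows. Statements on the series, on what has been measured and on what is new or still open speak of the compounds shown alone.

Measured compounds:
- compound 1, `COc1cc(NC(=O)Nc2cc(Nc3ccc(F)c(Cl)c3)ncn2)cc(OC)c1`: 53%
- compound 2, `COc1cc(Br)ccc1Nc1cc(NC(=O)Nc2c(Cl)cccc2Cl)ncn1`: 47.3%

Both were tested in a functional assay on NCI-H1581 cells (Homo sapiens) for inhibition, read by MTT assay, with a stated time of 48 h, tested at 10 uM; on this read-out lower numbers stand for less inhibition and higher numbers for more inhibition at the one concentration tested (going by the name of the read-out). Compound 1, the starting point of this step, gives 53%, which is the higher of the two numbers, while compound 2 gives 47.3%; the gap between them lies within the scatter of repeated measurements, so the two compounds cannot be told apart on this read-out. Compound 3, `COc1cc(NC(=O)Nc2cc(Nc3ccc(OC)c(C)c3)ncn2)cc(OC)c1`, has not yet been measured. It keeps the core of compound 1 and differs in one place: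

4-methoxy-3-methylphenyl in place of 3-chloro-4-fluorophenyl on a nitrogen on an aromatic ring

Within the data shown here, no measured pair in this set shows what such an exchange does, so the expectation rests on compound 1 alone. In this assay a step from compound 1 to compound 3 of a number 8 percentage points lower from compound 1 to compound 3 (within the scatter) is expected, that is, a change that stays within the scatter. Compound 3 is therefore estimated at 45%, with a range from 25% to 65%.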

Compound 3, a percentage reported as inhibition, at one concentration (the size of the read-out at that concentration, not a potency): 19.7%
Beside the measured number, compound 3's estimate is 25.3 percentage points above it; the whole stated range lies above it.
By their numbers in this assay, from the lowest: compound 3; then compounds 2 and 1 (each within the scatter of the next).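

Compounds 1 and 3 differ only in the group on this nitrogen, and they show that the read-out depends strongly on what sits there: in this assay, 4-methoxy-3-methylphenyl in place of 3-chloro-4-fluorophenyl gives a number 33.3 percentage points lower from compound 1 to compound 3 (beyond the scatter) with the rest of the molecule unchanged. Both groups are built on the same six-membered aromatic carbon ring, so the step follows the groups that ring carries and not the ring itself. Nothing measured here explains why this exchange lowers the number.

As far as these compounds go, all the groups on the ring change at once, so it remains open whether the loss follows the departure of the chlorine and fluorine or the arrival of the methoxy and methyl groups. From the compounds shown here alone, how a nitrile or a dimethylamino group on this ring would read also remains open.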